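A few compounds are considered here, and "the series" means these few. Any claim that something is new, unique, unknown or untested is made for them only; others in the source may bear on it.

Compound 1 `COc1cccc(/C(=C\c2cn(C(C)=O)c3ccc(OCc4ccccc4)cc23)C(=O)O)c1` gives 65100 nM in a functional assay on LNCaP cells (Homo sapiens) for cytotoxicity, read by MTT assay, with a stated time of 72 h; a higher number here means a weaker inhibitor, a lower number a stronger inhibitor. Compound 2 `COc1ccc(/C(=C\c2cn(C(C)=O)c3ccc(OCc4ccccc4)cc23)C(=O)O)cc1OC` sits at the limit of > 100000 nM in this assay, at which 1 of the 2 values shown sits. In this assay compound 2 gives > 100000 nM, which is a limit of the assay and not a number. Compound 3 `COc1ccc(/C(=C\c2cn(C(C)=O)c3ccc(OCc4ccccc4)cc23)C(=O)O)cc1` differs from compound 2 by hydrogen in place of methoxy on an aromatic carbon. Going by the values given here, the only measured step bearing on this change is an at least 1.5-fold higher number from compound 1 to compound 2 (0.18 log units; that floor lies within the scatter), which runs the opposite way and stays within the scatter, so in this assay a modest drop in the number, or none beyond the scatter, is expected. Compound 3 is therefore estimated at 70000 nM, between 25000 nM and 200000 nM. That estimate means a step of an at least 1.4-fold lower number from compound 2 to compound 3 (0.15 log units; that floor lies within the scatter).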

Compound 3, half-maximal inhibitory concentration: 85000 nM
Estimate against measurement, compound 3: 1.2-fold (0.08 log units) below; low and high end bracket the measured number.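

In this assay, the change from 3,4-dimethoxyphenyl to 4-methoxyphenyl gives a measured number in place of a limit, but the step is only an at least 1.1-fold lower number from compound 2 to compound 3 (0.07 log units; that floor lies within the scatter). Shifting the single methoxy, a comparison the earlier compounds did not offer, gives a 1.3-fold higher number from compound 1 to compound 3 (0.12 log units; within the scatter), so the 3-methoxyphenyl and 4-methoxyphenyl forms cannot be told apart here. The value of compound 2 is a limit of the assay and not a number: the limit of > 100000 nM in this assay, at which 1 of the 3 values shown sits.

Going by these compounds, it remains open whether a hydroxyl or an amine in place of the methoxy would move the number beyond the scatter. The same holds for an amide in place of the carboxylic acid.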